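This account rests on a few compounds, and the source may have more. Where it says the series, first, only, none or still open, it means among the compounds named here.

Of the compounds shown here, three sharing one core have been tested in a functional assay on DU-145 cells (Homo sapiens) for cytotoxicity, read by MTT assay, with a stated time of 24 h; on this read-out lower numbers stand for stronger inhibition and higher numbers for weaker inhibition. Compound 1 `COc1cc2nc(Cl)nc(NS(=O)(=O)c3ccccc3)c2cc1OC` gives 12.3 ug/mL. Compound 2 `COc1cc2nc(N3CCCC3)nc(NS(=O)(=O)c3cccc(C(F)(F)F)c3)c2cc1OC` gives 65.1 ug/mL, and compound 3 `COc1cc2nc(Cl)nc(NS(=O)(=O)c3cccc4ccccc34)c2cc1OC` gives 63.7 ug/mL. Compound 1 thus has the lowest number of the three, and the gaps to compound 2 and to compound 3 both lie beyond the usual scatter of such measurements, so compound 1 stands as the most potent of the set.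

Compound 4 `COc1cc2nc(Cl)nc(NS(=O)(=O)c3cccs3)c2cc1OC` has not yet been measured in this assay. It differs from compound 1 in one place: thiophen-2-yl in place of phenyl on a sulfonyl sulfur. Neither compound 2 nor compound 3 shows what a swap of this kind does, since each of them differs from compound 1 elsewhere as well; the expectation therefore rests on the change itself, an exchange of one small aromatic ring for another on the sulfonyl sulfur. The step of a 1.2-fold higher number from compound 1 to compound 4 (0.09 log units; within the scatter) is expected to stay within the scatter, with no clear direction. Compound 4 is therefore estimated at 15 ug/mL in this assay, within a range from 6 ug/mL to 40 ug/mL.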

Compound 4, half-maximal inhibitory concentration: 16.5 ug/mL
The estimate for compound 4 lay 1.1-fold (0.04 log units) below the measured number, within the range that was stated.
By their numbers in this assay, from the lowest: compounds 1 and 4 (each within the scatter of the next); then compounds 3 and 2 (each within the scatter of the next).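

For the compounds shown here, with only the ring on the sulfonyl sulfur exchanged, this pair gives the first direct reading of that position in this assay, and a 1.3-fold higher number from compound 1 to compound 4 (0.13 log units; within the scatter) stays within the scatter. On this read-out, then, the six-membered carbon ring of phenyl can give way to the five-membered thiophen-2-yl, with its ring sulfur, without a clear change in the number. Nothing measured here explains why these two rings read alike.

Still open, on these data alone, is whether this position would tolerate a pyridine ring, a saturated cyclohexyl ring or a simple methyl group in the same way. As far as these compounds go, it is also open whether thiophen-2-yl and phenyl would still read alike if the chlorine on the shared core were replaced by an amine.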